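Changing the aryl on the triazole: another limit expected

The compounds below may be only part of what the source reports. "The series", "measured", "known", "first", "only" and "open" are said of these compounds alone.

Measured in a functional assay on MCF7 cells (Homo sapiens) for antiproliferative activity, read by MTT assay, with a stated time of 48 h; on this read-out higher numbers stand for weaker inhibition and lower numbers for stronger inhibition:
Compound 1 `COc1ccccc1-n1nncc1CN1C(=O)C2(C(C#N)=C(N)Oc3c2c2nc4ccccc4nc2c2ccccc32)c2ccccc21`: > 50000 nM, a limit of the assay.
Compound 2 `N#CC1=C(N)Oc2c(c3nc4ccccc4nc3c3ccccc23)C12C(=O)N(Cc1cnnn1-c1ccc(N)cc1)c1ccccc12`: > 50000 nM, a limit of the assay.

Compound 2 therefore stands at the top of what this assay reports, with no number of its own. Among the compounds with values here, the only measured step, a step that the two limits leave unreadable from compound 1 to compound 2, cannot be read, since both ends are limits; the one piece of evidence is the limit of > 50000 nM in this assay, at which 2 of the 2 values shown sit. The new compound is compound 3 `Cc1ccc(C)c(-n2nncc2CN2C(=O)C3(C(C#N)=C(N)Oc4c3c3nc5ccccc5nc3c3ccccc43)c3ccccc32)c1`, reached from compound 2 by the change (2,5-dimethylphenyl in place of 4-aminophenyl on an aromatic nitrogen). Within the data shown here, no measured step bears on this change, and no measured value is a number, so nothing shows a direction or size for it. Among the measured compounds shown here, all that can be said is that every compound so far has reached the limit, and compound 3 is expected to do the same. The value of compound 3 is estimated at 50000 nM, within 20000 nM to 100000 nM. The expected step is a number no higher from compound 2 to compound 3 (the limit leaves the size open), which is to say no change that the assay could show.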

Compound 3, half-maximal inhibitory concentration: > 50000 nM
Compound 3 was reported as a limit; the forecaster's own chance of this, stated with the estimate: 75%; the middle value lies on the limit itself.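

Compound 3 gives only a limit in this assay, as do compound 1 and compound 2, so no step among these three compounds can be read. The compounds shown leave open whether 2-methoxyphenyl, 4-aminophenyl and 2,5-dimethylphenyl differ at all in this assay, and what actual number each compound would have.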